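Adding a chloro group to compound 3

This account rests on a few compounds, and the source may have more. Where it says the series, first, only, none or still open, it means among the compounds named here.

Measured in a functional assay on NCI/ADR-RES cells (Homo sapiens) for inhibition, read by sulforhodamine B assay, with a stated time of 48 h; a lower number here means a stronger inhibitor of growth, a higher number a weaker inhibitor of growth:
Compound 1 `CN(C)/C=C/C(=O)c1nn(-c2ccccc2)c(-c2ccccc2)c1C#N`: 90600 nM
Compound 2 `Cc1nnc(-c2nn(-c3ccccc3)c(-c3ccccc3)c2C#N)c2cn(-c3ccccc3)nc12`: > 100000 nM, which is a limit of the assay
Compound 3 `N#Cc1c(-c2nnc(O)c3nn(-c4ccccc4)cc23)nn(-c2ccccc2)c1-c1ccccc1`: 2760 nM

Compound 3, at 2760 nM, has the lowest number of the series, well under compound 1 at 90600 nM. The value of compound 2 is only a limit, as the limit of > 100000 nM in this assay, at which 1 of the 3 values shown sits, records.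

Compound 4 `N#Cc1c(-c2nnc(O)c3nn(-c4ccc(Cl)cc4)cc23)nn(-c2ccccc2)c1-c1ccccc1` is compound 3 with one change, phenyl to 4-chlorophenyl: chloro in place of hydrogen on an aromatic carbon. This places chloro in place of hydrogen on an aromatic carbon, para to a large group.

For the measured compounds named here, only one measured step changes a single place, an at least 36-fold lower number from compound 2 to compound 3 (1.55 log units; beyond the scatter). It is large, but it puts hydroxy in place of methyl, a different change at a different place, so it says little here. Going by the values given here, no measured compound carries a chloro group, so neither direction is favoured in this assay. The expected step is a 1.1-fold lower number from compound 3 to compound 4 (0.04 log units; within the scatter), which would lie within the scatter. For compound 4 the estimated value is 2500 nM, with an expected range from 800 nM to 8000 nM.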

Compound 4, concentration for 50% growth inhibition: > 100000 nM
Compound 4: a limit, no number (the forecaster's own chance of this, stated with the estimate: 3%); at least 40-fold (1.60 log units) between middle value and limit.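

In this assay, the change from phenyl to 4-chlorophenyl gives an at least 36-fold higher number from compound 3 to compound 4 (1.55 log units; beyond the scatter), so a single added chlorine atom is enough to remove the growth inhibition seen with compound 3 from the measurable range. Compound 4 has no number, only a limit of the assay: the limit of > 100000 nM in this assay, at which 2 of the 4 values shown sit. For the compounds shown here, none of the earlier compounds carries a group on this ring, and this step is the first to show that the place para to a large group is far from indifferent to a change.

Going by these compounds, the true size of the step stays open, as does the question of whether the loss belongs to chloro alone or to any group at this place. A fluoro group, a methoxy group or an amine at the same carbon would help to separate these possibilities.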